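The source may report more compounds than this note shows. Statements on the series, on what has been measured and on what is new or still open speak of the compounds shown alone.

Working notes on the series.

Compound 3 `CS(=O)(=O)Nc1cccc(-c2cc(C(O)(C(F)(F)F)C(F)(F)F)cnc2N2CCN(S(=O)(=O)c3ccc(N)nc3)CC2)c1` holds the highest of the three numbers in an ADME assay (liver) for metabolic stability, with Liver microsome (Homo sapiens) as the target, using microsomes and NADPH, with a stated time of 30 min, tested at 1 uM; a lower number here means slower removal, a higher number faster removal of the compound; in this assay compound 3 gives 40 mL.min-1.g-1. Compound 1 `Nc1ccc(S(=O)(=O)N2CCN(c3ncc(C(O)(C(F)(F)F)C(F)(F)F)cc3C3CC3)CC2)cn1` gives 38 mL.min-1.g-1 and compound 2 `Cn1cc(-c2cc(C(O)(C(F)(F)F)C(F)(F)F)cnc2N2CCN(S(=O)(=O)c3ccc(N)nc3)CC2)cn1` gives 19 mL.min-1.g-1. The gap from compound 1 is a 1.1-fold higher number from compound 1 to compound 3 (0.02 log units; within the scatter), while the gap from compound 2 is a 2.1-fold higher number from compound 2 to compound 3 (0.32 log units; beyond the scatter). Compound 4 `Cc1nc2cc(-c3cc(C(O)(C(F)(F)F)C(F)(F)F)cnc3N3CCN(S(=O)(=O)c4ccc(N)nc4)CC3)ccc2o1` differs from compound 3 by 2-methyl-1,3-benzoxazol-5-yl in place of 3-(methanesulfonamido)phenyl on an aromatic carbon. All three changes made at this aromatic carbon moved the number only a little: a 2.0-fold lower number from compound 1 to compound 2 (0.30 log units; within the scatter), a 1.1-fold higher number from compound 1 to compound 3 (0.02 log units; within the scatter), a 2.1-fold higher number from compound 2 to compound 3 (0.32 log units; beyond the scatter). No step beyond the scatter is therefore expected for compound 4, with perhaps a slight drift toward a lower number. Compound 4 is expected to give 30 mL.min-1.g-1, within a range from 14 mL.min-1.g-1 to 65 mL.min-1.g-1. This estimate means a step of a 1.3-fold lower number from compound 3 to compound 4 (0.12 log units; within the scatter), expected to stay within the scatter.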

Compound 4, intrinsic clearance in microsomes: < 14 mL.min-1.g-1
Compound 4 ended at the assay's limit (the forecaster's own chance of this, stated with the estimate: 5%); at least 2.1-fold (0.33 log units) between middle value and limit.
By their numbers in this assay, from the lowest: compounds 2, 1 and 3 (each within the scatter of the next, the first and the last beyond it). At a limit, below all of these: compound 4.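

In this assay compound 4 stands at a limit and not at a number: the limit of < 14 mL.min-1.g-1 in this assay, at which 1 of the 4 values shown sits. Within the data shown here, at this aromatic carbon, 2-methyl-1,3-benzoxazol-5-yl gives an at least 2.8-fold lower number from compound 3 to compound 4 (0.45 log units; beyond the scatter) and an at least 2.7-fold lower number from compound 1 to compound 4 (0.43 log units; beyond the scatter), so the position spans a wider range than the earlier compounds showed. The remaining step, an at least 1.3-fold lower number from compound 2 to compound 4 (0.13 log units; that floor lies within the scatter), settles nothing firm for that pair.

From the compounds shown here alone, how far the true number of compound 4 lies past the limit stays open. Also open, going by these compounds, is whether a plain phenyl, a benzoxazol-5-yl lacking the methyl, or an amine at this carbon would reach the same limit.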